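The source may report more compounds than this note shows. Statements on the series, on what has been measured and on what is new or still open speak of the compounds shown alone.

For the measured compounds named here, compound 1, `O=C1COc2ccc(NC(=O)C3CCN(c4ccccc4Cl)CC3)cc2N1`, gives 220 nM in a functional assay for antagonist activity at transient receptor potential cation channel subfamily V member 1 (Homo sapiens), read by FLIPR and calcium flux (on this read-out higher numbers stand for weaker inhibition and lower numbers for stronger inhibition), and holds the lower of the two numbers measured so far; compound 2, `O=C(Nc1cnc2ccccc2c1)C1CCN(c2cccc(C(F)(F)F)c2)CC1`, gives 600 nM in this assay, and the gap between compound 1 and compound 2 lies beyond the scatter. Compound 3, `O=C1COc2ccc(NC(=O)C3CCN(c4ccccc4C(F)(F)F)CC3)cc2N1`, remains to be measured. The change from compound 1 to compound 3 is trifluoromethyl in place of chloro on an aromatic carbon. Going by the values given here, no measured pair shows this change, so its direction is open; a step of modest size at most in this assay is expected, most likely none beyond the scatter. For compound 3 the expected step is a 1.1-fold lower number from compound 1 to compound 3 (0.04 log units; within the scatter). Compound 3 is estimated at 200 nM, with a range from 70 nM to 600 nM.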

Compound 3, half-maximal inhibitory concentration: 380 nM
Estimate against measurement, compound 3: 1.9-fold (0.28 log units) below, and the stated range covers the measured number.
By their numbers in this assay, from the lowest: compounds 1, 3 and 2 (each within the scatter of the next, the first and the last beyond it).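

In this assay, trifluoromethyl in place of chloro on this aromatic carbon, ortho to a large group, gives a 1.7-fold higher number from compound 1 to compound 3 (0.24 log units; within the scatter) on the shared core. This first single-place pair in the series shows that the position accepts 4 heavy atoms in place of 1 with no step beyond the scatter. No measurement on hand bears on the reason for this step. Open remain a methoxy group, a nitrile or an amine on this same carbon, and whether the change reads alike on the core of compound 2.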